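From pyridin-4-yl to 6-methylpyridin-3-yl on the shared core

The source may report more compounds than this note shows. Statements on the series, on what has been measured and on what is new or still open speak of the compounds shown alone.

In an ADME assay (liver) for metabolic stability, with Liver microsome (Rattus norvegicus) as the target, using microsomes and NADPH, with a stated time of 30 min, tested at 1 uM (a lower number here means slower removal, a higher number faster removal of the compound), compound 1 `CCn1cc(-c2cc(C(O)(C(F)(F)F)C(F)(F)F)cnc2N2CCN(S(=O)(=O)c3ccc(N)nc3)CC2)cn1` gives 194 mL.min-1.g-1, while compound 2 `Nc1ccc(S(=O)(=O)N2CCN(c3ncc(C(O)(C(F)(F)F)C(F)(F)F)cc3-c3ccncc3)CC2)cn1` gives 31 mL.min-1.g-1, the lower of the two numbers. Among the measured compounds shown here, only one measured step bears on what follows: a 6.3-fold lower number from compound 1 to compound 2 (0.80 log units; beyond the scatter), a modest step beyond the scatter, in which pyridin-4-yl stands in place of 1-ethyl-1H-pyrazol-4-yl. Compound 3 `Cc1ccc(-c2cc(C(O)(C(F)(F)F)C(F)(F)F)cnc2N2CCN(S(=O)(=O)c3ccc(N)nc3)CC2)cn1` keeps the core of compound 2 and changes the same aromatic carbon, with 6-methylpyridin-3-yl in place of pyridin-4-yl on an aromatic carbon. For the measured compounds named here, no measured compound carries this group, so the evidence is indirect. With compound 2 at the low end of just two numbers, a rise is expected, though one smaller than a 6.3-fold lower number from compound 1 to compound 2 (0.80 log units; beyond the scatter). The expected change is a 2.1-fold higher number from compound 2 to compound 3 (0.32 log units; beyond the scatter). For compound 3 the estimated value in this assay is 65 mL.min-1.g-1, with an expected range of 25 mL.min-1.g-1 to 170 mL.min-1.g-1.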

Compound 3, intrinsic clearance in microsomes: 182 mL.min-1.g-1
For compound 3 the middle estimate is 2.8-fold (0.45 log units) below the measured one, outside the stated range (above it).
By their numbers in this assay, from the lowest: compound 2; then compounds 3 and 1 (each within the scatter of the next).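

In this assay, replacing pyridin-4-yl with 6-methylpyridin-3-yl on this aromatic carbon gives a 5.9-fold higher number from compound 2 to compound 3 (0.77 log units; beyond the scatter) and shows that the low number of compound 2 does not extend to every six-membered aromatic ring with 1 hetero atom at this position. The other new step, a 1.1-fold lower number from compound 1 to compound 3 (0.03 log units; within the scatter) and so within the scatter, leaves 6-methylpyridin-3-yl and 1-ethyl-1H-pyrazol-4-yl indistinguishable here, with only pyridin-4-yl standing apart among the three groups shown. No measurement offered here accounts for the difference between these groups. The change from compound 2 to compound 3 moves the point of attachment and adds the methyl group together, and the compounds shown do not separate the two. Unsubstituted pyridin-3-yl would separate them, while a 2-aminopyridin-4-yl group would show whether a substituent on the pyridin-4-yl ring keeps the lower number.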